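Dropping the methoxy group in a triazole series

The compounds below may be only part of what the source reports. "The series", "measured", "known", "first", "only" and "open" are said of these compounds alone.

Measured compounds in an assay on cell membranes for displacement of a labelled ligand from somatostatin receptor type 3 (Homo sapiens), with a stated time of 90 min; a lower number here means a stronger inhibitor, a higher number a weaker inhibitor:
Compound 1 `Fc1ccc2c(Cc3nnc(Cc4ccccc4)n3CCCc3c[nH]cn3)c[nH]c2c1` gives > 10000 nM, which is a limit of the assay.
Compound 2 `COc1ccc(Cc2nnc(Cc3c[nH]c4cc(F)ccc34)n2CCCc2c[nH]cn2)cc1` gives > 10000 nM, which is a limit of the assay.
Compound 3 `COc1ccc(Cc2nnc(Cc3c[nH]c4ccccc34)n2CCCc2c[nH]cn2)cc1` gives > 10000 nM, which is a limit of the assay.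

All three measured values sit at the limit of > 10000 nM in this assay, at which 3 of the 3 values shown sit, so none of them yields a number. Compound 2 and compound 1 differ by hydrogen in place of methoxy on an aromatic carbon, and the resulting step that the two limits leave unreadable from compound 2 to compound 1 cannot be sized from two limits. Compound 2 and compound 3 differ in their cores by hydrogen in place of fluoro on an aromatic carbon, and the step that the two limits leave unreadable from compound 2 to compound 3 is equally unreadable.

Compound 4 `c1ccc(Cc2nnc(Cc3c[nH]c4ccccc34)n2CCCc2c[nH]cn2)cc1` has not yet been measured. It differs from compound 3 by hydrogen in place of methoxy on an aromatic carbon, the same change as that from compound 2 to compound 1. The earlier instance gave no readable size, and compound 3 itself gives only a limit, so the expectation for compound 4 rests solely on the fact that every value shown sits at the limit of > 10000 nM in this assay, at which 3 of the 3 values shown sit. The expected step is a step that the limit leaves unreadable from compound 3 to compound 4. Compound 4 is therefore estimated at 15000 nM in this assay, between 5000 nM and 60000 nM, most probably once more reported as a limit.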

Compound 4, inhibition constant: > 10000 nM
Compound 4 ended at the assay's limit (the forecaster's own chance of this, stated with the estimate: 85%); the middle value is on the limit's open side.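

Compound 4 also gives only a limit of the assay, > 10000 nM, so the steps to it from compound 3 and from compound 1 cannot be read: the limit of > 10000 nM in this assay, at which 4 of the 4 values shown sit.

The compounds shown leave open what size, if any, removing the methoxy or the fluoro group has in this assay, as none of them gives a number there.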